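The compounds below may be only part of what the source reports. "The series", "measured", "known", "first", "only" and "open" are said of these compounds alone.

Measured in an assay on IMR-32 cells for inhibition of Voltage-dependent N-type calcium channel subunit alpha-1B (Homo sapiens); on this read-out higher numbers stand for weaker inhibition and lower numbers for stronger inhibition:
compound 1 `COc1ccc(COC(=O)[C@H](CSCC2CCCCC2)NC(=O)OC(C)(C)C)cc1` gives 610 nM;
compound 2 `COc1ccc(COC(=O)[C@H](CSCC2CCCCC2)NC(=O)[C@@H]2CSCN2C(=O)OC(C)(C)C)cc1` gives 390 nM;
compound 3 `COc1ccc(COC(=O)[C@H](CSCC2CCCCC2)NC(=O)[C@@H]2CSCN2)cc1` gives 2700 nM.

Among the compounds with values here, compound 2 has the lowest number of the three, but its gap to compound 1, a 1.6-fold lower number from compound 1 to compound 2 (0.19 log units; within the scatter), is within the scatter, so no order between them is claimed; only the step of a 6.9-fold higher number from compound 2 to compound 3 (0.84 log units; beyond the scatter) is beyond it.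

Compound 4 `CC(C)(C)OC(=O)N1CSC[C@H]1C(=O)N[C@@H](CSCC1CCCCC1)C(=O)NCc1ccc([N+](=O)[O-])cc1` differs from compound 2 at the other end of the core: (4-nitrobenzyl)amino in place of (4-methoxybenzyl)oxy on a carbonyl carbon. Within the data shown here, none of the measured steps touches this carbonyl; all three (a 1.6-fold lower number from compound 1 to compound 2 (0.19 log units; within the scatter), a 4.4-fold higher number from compound 1 to compound 3 (0.65 log units; beyond the scatter), a 6.9-fold higher number from compound 2 to compound 3 (0.84 log units; beyond the scatter)) concern the amide side. The step that is expected here, a 1.3-fold higher number from compound 2 to compound 4 (0.11 log units; within the scatter), is therefore an estimate only, with no shown step to settle its direction. Compound 4 is therefore expected near compound 2, at 500 nM, within a wide range of 150 nM to 2000 nM.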

Compound 4, half-maximal inhibitory concentration: 600 nM
The estimate for compound 4 lay 1.2-fold (0.08 log units) below the measured number; measured number inside the range.
By their numbers in this assay, from the lowest: compounds 2, 4 and 1 (each within the scatter of the next); then compound 3.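

In this assay, within the data shown here, unlike the earlier steps, this one changes the carbonyl at the other end of the core, and a 1.5-fold higher number from compound 2 to compound 4 (0.19 log units; within the scatter) stays within the scatter. Replacing (4-methoxybenzyl)oxy with (4-nitrobenzyl)amino, which adds a hydrogen-bond donor, therefore leaves no readable difference, although the linking atom and the ring substituent change together. No evidence is available to explain this result.

Still open, as far as these compounds go, is whether a (4-methoxybenzyl)amino or a 4-nitrobenzyl ester group would give a similar number, separating the two changes. From the compounds shown here alone, a free carboxylic acid on this carbonyl also remains untested here.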